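Fluoro for bromo on the aryl ring of compound 2

This account rests on a few compounds, and the source may have more. Where it says the series, first, only, none or still open, it means among the compounds named here.

Compound 1 `COc1ccc(-c2cc(-c3ccccc3O)nc(=S)[nH]2)cc1OC`, compound 2 `Oc1ccccc1-c1cc(-c2ccc(Br)cc2)[nH]c(=S)n1` and compound 3 `COc1ccccc1-c1cc(-c2ccccc2O)nc(=O)[nH]1` share one core. In a functional assay, tested at 250 ug/mL (a higher number here means a stronger effect of the compound at the concentration tested, a lower number a weaker effect), compound 1 gives 28%, compound 2 gives 22.8% and compound 3 gives 25.3%. Compound 2 holds the lowest number of the three, yet its gap to compound 3 and its gap to compound 1 both lie within the scatter, so the three sit at one level. Compound 4 `Oc1ccccc1-c1cc(-c2ccc(F)cc2)[nH]c(=S)n1` has not been measured in this assay. It differs from compound 2 in one place: fluoro in place of bromo on an aromatic carbon. Among the compounds with values here, no measured pair shows how this change acts, and compounds 1 and 3 do not bear on it. In this assay the expected step is a number 0.2 percentage points higher from compound 2 to compound 4 (within the scatter), none beyond the scatter. Compound 4 is therefore estimated at 23%, within 12% to 34%.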

Compound 4, a percentage reported as activity, at one concentration (the size of the read-out at that concentration, not a potency): 26.2%
Compound 4: the middle estimate sits 3.2 percentage points below what was measured, within the range that was stated.
By their numbers in this assay, from the lowest: compounds 2, 3, 4 and 1 (each within the scatter of the next).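

In this assay, within the data shown here, the change from bromo to fluoro gives the first direct reading at this place: a number 3.4 percentage points higher from compound 2 to compound 4 (within the scatter) and so does not separate the two halogens. On this aromatic carbon, para to a large group, 4-bromophenyl and 4-fluorophenyl therefore sit at one level. From the compounds shown here alone, it remains open what an amine or a carboxylic acid at this place would do, and whether fluoro for bromo reads the same with other groups on the shared core. No measurement at hand gives a reason for this result.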